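The compounds below may be only part of what the source reports. "The series", "measured", "known", "first", "only" and "open" are said of these compounds alone.

Compound 1 `C#CCN(C)CCCCCOc1ccc2c(c1)CCC2=O` and compound 2 `C#CCN(C)CCCCCCOc1ccc2c(c1)CCC2=O` share one core, and compound 3 `C#CCN(C)CCCCCOc1ccc(C=O)c(OC)c1` and compound 4 `C#CCN(C)CCCCCCOc1ccc(C=O)c(OC)c1` share another. How the two cores differ is not broken down here. In an assay on BTI cells for inhibition of Amine oxidase [flavin-containing] B (Homo sapiens), read by fluorescence and Amplex Red, with a stated time of 15 min (on this read-out higher numbers stand for weaker inhibition and lower numbers for stronger inhibition), compound 1 gives 94.8 nM, and compound 2 gives 129 nM. The two compounds differ in one place, by (methyl(propargyl)amino)methyl in place of methyl(propargyl)amino on a saturated chain carbon, five bonds along the chain from an oxygen on an aromatic ring. That change made a step of a 1.4-fold higher number from compound 1 to compound 2 (0.13 log units; within the scatter). Compound 3 stands apart: in this assay compound 3 gives 5740 nM, a higher number than either compound 1 or compound 2, and this gap lies beyond the scatter in both cases.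

Compound 4 is not yet measured. It differs from compound 3 by (methyl(propargyl)amino)methyl in place of methyl(propargyl)amino on a saturated chain carbon, five bonds along the chain from an oxygen on an aromatic ring. This is the same change that separates compound 1 from compound 2, made on the other core, and among the four compounds it occurs twice in all. Going by the values given here, since the one measured instance of the change, the step from compound 1 to compound 2, stayed within the scatter, the expectation is that the same change on compound 3 also moves the number little, an estimated step of a 1.3-fold higher number from compound 3 to compound 4 (0.12 log units; within the scatter). Among the compounds with values here, compound 4 is therefore expected to give about 7500 nM in this assay, with a range from 3000 nM to 18000 nM, because compound 3 gives 5740 nM and the single measured instance of the change was small.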

Compound 4, half-maximal inhibitory concentration: 552 nM
Estimate against measurement, compound 4: 14-fold (1.13 log units) above, and the stated range ends above it.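

In this assay, the change from methyl(propargyl)amino to (methyl(propargyl)amino)methyl gives a 10-fold lower number from compound 3 to compound 4 (1.02 log units; beyond the scatter), a large step on this core. Going by these compounds alone, a change that barely moved the number on one core therefore moved it strongly on the other, so the size of its effect did not carry across these two cores: the same change on two cores in this assay, a 1.4-fold higher number (0.13 log units; within the scatter) from compound 1 to compound 2 and a 10-fold lower number (1.02 log units; beyond the scatter) from compound 3 to compound 4, 14-fold (1.15 log units) apart, beyond the scatter of two such steps This does not show why the two cores behave differently, and with only two instances of the change, it cannot show which size to expect on a third core, or whether the direction would hold there.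

The compounds shown leave open whether a still longer chain between the ring oxygen and the nitrogen would continue to lower the number on the core of compound 3, or would leave it flat as on the core of compound 1. They also leave open whether the gap between the two cores would persist if an ethyl group took the place of the methyl on the nitrogen.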